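Replacing Thiophene by Isothiazole: Expected Maximal Response

A few compounds are considered here, and "the series" means these few. Any claim that something is new, unique, unknown or untested is made for them only; others in the source may bear on it.

In a functional assay with Alpha-1A adrenergic receptor (Homo sapiens) as the target, read by calcium flux (a lower number here means a smaller maximal response, a higher number a larger maximal response), the three measured compounds gave the following:
compound 1 `c1cnc(-c2ccccc2OCC2=NCCN2)nc1`: 90%
compound 2 `c1csc(-c2ccccc2OCC2=NCCN2)c1`: 101%
compound 3 `c1ccc(-c2ccsc2)c(OCC2=NCCN2)c1`: 98%

Compound 3 stands second highest of these three numbers. Its nearest neighbour is compound 2, where a number 3 percentage points lower from compound 2 to compound 3 (within the scatter), and its furthest is compound 1, where a number 8 percentage points higher from compound 1 to compound 3 (within the scatter); both of these gaps fall inside the usual scatter of repeated measurements. For the measured compounds named here, the only step that reaches beyond the scatter is a number 11 percentage points higher from compound 1 to compound 2 (beyond the scatter), and even that is modest.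

Compound 4 `c1ccc(-c2ccns2)c(OCC2=NCCN2)c1` is not yet measured. It differs from compound 3 in one place: 1,2-thiazol-5-yl in place of thiophen-3-yl on an aromatic carbon. Going by the values given here, the steps that bear on this are the three ring exchanges above, all of which moved the maximal response little, with every value lying close to the full control response. The step of a number 3 percentage points lower from compound 3 to compound 4 (within the scatter) is therefore expected to stay within the scatter. Compound 4 is estimated to give 95% in this assay, with a range from 82% to 106%.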

Compound 4, largest response reached (reported as maximum), in percent of the reference or control that the assay uses: 99%
For compound 4 the middle estimate is 4 percentage points below the measured one; the range from low to high includes it.
By their numbers in this assay, from the lowest: compounds 1, 3, 4 and 2 (each within the scatter of the next, the first and the last beyond it).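

In this assay, 1,2-thiazol-5-yl in place of thiophen-3-yl gives a number 1 percentage points higher from compound 3 to compound 4 (within the scatter), so at this position a five-membered aromatic ring with 2 hetero atoms and 2 hydrogen-bond acceptors serves as well as one with 1 hetero atom and 1 hydrogen-bond acceptor. The other two comparisons read the same way, with a number 2 percentage points lower from compound 2 to compound 4 (within the scatter) and a number 9 percentage points higher from compound 1 to compound 4 (within the scatter), so compound 4 cannot be told apart from any earlier compound, even though compound 1 and compound 2 differ beyond the scatter. Nothing available here explains why these exchanges change the response so little.

From the compounds shown here alone, every group compared at this position is an aromatic ring, so it remains open whether a carboxylic acid, an amine or a longer alkyl chain there would keep the response. This read-out also gives only the largest response reached, leaving open how much of each compound is needed to reach it.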